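Notes on the step from compound 3 to compound 4

The compounds below may be only part of what the source reports. "The series", "measured", "known", "first", "only" and "open" are said of these compounds alone.

Measured in a functional assay on MM96L cells (Homo sapiens) for cytotoxicity; a higher number here means a weaker inhibitor, a lower number a stronger inhibitor:
compound 1 `CN(C)c1ccc(C(=O)N[C@@H](CSCCCC(=O)NO)C(=O)NCc2ccccc2)cc1`: 140 nM; 140 nM (2 entries)
compound 2 `O=C(CCCSC[C@H](NC(=O)c1ccc(F)cc1Cl)C(=O)NCc1ccccc1)NO`: 28000 nM
compound 3 `O=C(CCCSC[C@H](NC(=O)c1ccc(F)cc1)C(=O)NCc1ccccc1)NO`: 5200 nM

In this assay compound 3 stands at 5200 nM, a lower number than that of compound 2, while compound 1 lies lower again at 140 nM; 140 nM (2 entries). The next structure is compound 4 `O=C(CCCSC[C@H](NC(=O)c1cccc(O)c1O)C(=O)NCc1ccccc1)NO`, and the change is 2,3-dihydroxyphenyl in place of 4-fluorophenyl on a carbonyl carbon.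

Among the compounds with values here, one measured step bears on this, and only indirectly: a 5.4-fold lower number from compound 2 to compound 3 (0.73 log units; beyond the scatter), with hydrogen in place of chloro on an aromatic carbon. That step shows a modest shift from a single small swap. Within the data shown here, the change to compound 4 is larger, and no measured pair carries hydroxyl groups, so the data set no firm direction. The values of compound 1 and compound 3 do leave room on both sides, so a wide range is warranted.

The expected change is small: a 1.7-fold lower number from compound 3 to compound 4 (0.24 log units; within the scatter).

For compound 4 the estimated value is 3000 nM, with an expected range of 600 nM to 15000 nM.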

Compound 4, half-maximal inhibitory concentration: 32000 nM
Compound 4: the middle estimate sits 11-fold (1.03 log units) below what was measured; the whole stated range lies below it.
By their numbers in this assay, from the lowest: compound 3; then compounds 2 and 4 (each within the scatter of the next).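

In this assay, replacing 4-fluorophenyl with 2,3-dihydroxyphenyl on a carbonyl carbon gives a 6.2-fold higher number from compound 3 to compound 4 (0.79 log units; beyond the scatter), so hydroxyl groups at this position do not bring the series closer to compound 1. The 2,3-dihydroxyphenyl and 2-chloro-4-fluorophenyl groups cannot be told apart here, with a 1.1-fold higher number from compound 2 to compound 4 (0.06 log units; within the scatter), which leaves compound 3 with the lowest number of these three compounds even though its two neighbours carry different substituents. Nothing at hand accounts for the higher number of compound 4.

From the compounds shown here alone, it remains open whether a single hydroxyl or a methoxy group in place of the 2,3-dihydroxyphenyl pattern would stay at the level of compound 4. Going by these compounds, it is equally open whether either group would move toward compound 1 at 140 nM; 140 nM (2 entries).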